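The source may report more compounds than this note shows. Statements on the series, on what has been measured and on what is new or still open speak of the compounds shown alone.

Compound 1 `CCOc1ccc(NC(=O)Nc2cccc(CNc3nccnc3Cl)c2)cc1` gives 7050 nM in a functional assay on HepG2 cells (Homo sapiens) for antiproliferative activity, read by MTT assay, with a stated time of 48 h; on this read-out lower numbers stand for stronger inhibition and higher numbers for weaker inhibition.
Compound 2 `COc1ccc(NC(=O)Nc2cccc(CNc3nccnc3Cl)c2)cc1` gives 12000 nM in this assay.
Compound 3 `Cc1cccc(NC(=O)Nc2cccc(CNc3nccnc3Cl)c2)c1` gives 11200 nM in this assay.

Going by the values given here, compound 1 has the lowest of the three numbers, but the gap to compound 3 a 1.6-fold higher number from compound 1 to compound 3 (0.20 log units; within the scatter) and the gap to compound 2 a 1.7-fold higher number from compound 1 to compound 2 (0.23 log units; within the scatter) both fall within the scatter, so no compound can be set apart from the others. The same holds for the step of a 1.1-fold lower number from compound 2 to compound 3 (0.03 log units; within the scatter).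

Compound 4 `Cc1ccc(NC(=O)Nc2cccc(CNc3nccnc3Cl)c2)c(C)c1` differs from compound 1 in one place: 2,4-dimethylphenyl in place of 4-ethoxyphenyl on an amide-type nitrogen. The step from compound 1 to compound 3, which also removes the 4-ethoxyphenyl in favour of a methyl-bearing phenyl on the amide-type nitrogen, stayed within the scatter, and the step from compound 2 to compound 3 did likewise. The three measured compounds therefore give no sign that the group on this nitrogen moves the number beyond the scatter, and for compound 4 a step of a 1.4-fold higher number from compound 1 to compound 4 (0.15 log units; within the scatter) is expected, at most a small shift toward a higher number. On that basis compound 4 is estimated at 10000 nM in this assay, with a range from 4000 nM to 25000 nM.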

Compound 4, half-maximal inhibitory concentration: 9290 nM
Compound 4: the middle estimate sits 1.1-fold (0.03 log units) above what was measured; the range from low to high includes it.
By their numbers in this assay, from the lowest: compounds 1, 4, 3 and 2 (each within the scatter of the next).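

With 2,4-dimethylphenyl on the amide-type nitrogen, the number in this assay again stays within the scatter of all three earlier compounds (a 1.3-fold higher number from compound 1 to compound 4 (0.12 log units; within the scatter); a 1.2-fold lower number from compound 3 to compound 4 (0.08 log units; within the scatter); a 1.3-fold lower number from compound 2 to compound 4 (0.11 log units; within the scatter)). The change from 4-ethoxyphenyl also takes away the oxygen and its hydrogen-bond acceptor, and this too leaves no mark beyond the scatter, so across these four groups the position shows no measurable preference. Nothing available offers an explanation for this result.

From the compounds shown here alone, it remains open whether an amine or a carboxylic acid on this phenyl ring, or a chain longer than ethoxy, would move the number beyond the scatter. All four compounds share the rest of the core, so the effect of a change elsewhere is also unknown.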